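Adding methoxy to the benzoyl of compound 2

The compounds below may be only part of what the source reports. "The series", "measured", "known", "first", "only" and "open" are said of these compounds alone.

In a functional assay on MDA-MB-231 cells (Homo sapiens) for antiproliferative activity, with a stated time of 4 days (a higher number here means a weaker inhibitor, a lower number a stronger inhibitor), compound 2 `CCCCc1ccc2[nH]c(-c3ccc(OC)cc3)c(/C=N/NC(=O)c3ccccc3)c2c1` gives 32 nM and sits within the scatter of compound 1 `CCCCc1ccc2[nH]c(-c3ccc(CC)cc3)c(C=O)c2c1` at 27 nM in that read-out, whereas compound 3 `CCCCc1ccc2[nH]c(-c3ccc(C(F)(F)F)cc3)c(/C=N/NC(=O)c3ccccc3)c2c1` gives 300 nM on the same scale. Compound 4 `CCCCc1ccc2[nH]c(-c3ccc(OC)cc3)c(/C=N/NC(=O)c3ccc(OC)cc3)c2c1` differs from compound 2 by methoxy in place of hydrogen on an aromatic carbon and so turns benzoyl into (4-methoxyphenyl)carbonyl. For the measured compounds named here, the one measured step, a 9.4-fold higher number from compound 2 to compound 3 (0.97 log units; beyond the scatter) and beyond the scatter, leaves the benzoyl unchanged, so it offers only weak guidance here. Going by the values given here, with no measured step at that group, little change is expected in this assay overall. The estimated step is a 1.3-fold higher number from compound 2 to compound 4 (0.10 log units; within the scatter) and lies within the scatter. Compound 4 is expected at 40 nM with an estimated range from 12 nM to 130 nM in this measurement.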

Compound 4, half-maximal inhibitory concentration: 61 nM
Beside the measured number, compound 4's estimate is 1.5-fold (0.18 log units) below it, within the range that was stated.
By their numbers in this assay, from the lowest: compounds 1, 2 and 4 (each within the scatter of the next, the first and the last beyond it); then compound 3.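

In this assay, methoxy in place of hydrogen on the benzoyl gives a 1.9-fold higher number from compound 2 to compound 4 (0.28 log units; within the scatter), so this para position accepts the added methoxy without a change beyond the scatter. For the compounds shown here, the only earlier step, a 9.4-fold higher number from compound 2 to compound 3 (0.97 log units; beyond the scatter), left the benzoyl unchanged, which makes this the first measured reading at that group. Nothing measured here offers an explanation for this result. Still open, as far as these compounds go, is whether a different group at this position, such as an amine or a carboxylic acid, would also stay within the scatter of compound 2.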